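Triple Bond for Double Bond: What Compound 4 May Show

The source may hold more compounds than are shown below. What is called first, only, known or untested is meant among the compounds shown, and "the series" means these compounds.

compound 1 `c1ccc(CCc2ccccc2CSc2nccs2)cc1`: 31%
compound 2 `Clc1ccc2[nH]c(SCc3ccccc3/C=C\c3ccccc3)nc2c1`: 49%
compound 3 `c1ccc(CCc2ccccc2CSC2=NCCN2)cc1`: 17%

In an assay on isolated protein for inhibition of Indoleamine 2,3-dioxygenase 1 (Homo sapiens), with a stated time of 60 min, tested at 10 uM (a higher number here means more inhibition at the concentration tested (going by the name of the read-out), a lower number less inhibition), compound 2 gives 49%, the highest of the three numbers; compound 1 sits lower at 31% and compound 3 lowest at 17%, both beyond the scatter. Within the data shown here, the one measured step, a number 14 percentage points lower from compound 1 to compound 3 (beyond the scatter), concerns the ring on the sulfur and says nothing about the two-carbon link between the aryl groups, so no measured step bears on the change at hand. Compound 4 `Clc1ccc2[nH]c(SCc3ccccc3C#Cc3ccccc3)nc2c1` differs from compound 2 only there: 2-phenylethynyl in place of 2-phenylethenyl on an aromatic carbon. Among the measured compounds shown here, with no guiding step, compound 4 is expected to stay close to compound 2, a change of a number 2 percentage points lower from compound 2 to compound 4 (within the scatter) within the scatter. Compound 4 is therefore estimated at 47%, between 30% and 65%.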

Compound 4, a percentage reported as inhibition, at one concentration (the size of the read-out at that concentration, not a potency): 52%
Estimate against measurement, compound 4: 5 percentage points below, within the range that was stated.
By their numbers in this assay, from the lowest: compound 3; then compound 1; then compounds 2 and 4 (each within the scatter of the next).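

In this assay, 2-phenylethynyl in place of 2-phenylethenyl on an aromatic carbon, ortho to a large group, gives a number 3 percentage points higher from compound 2 to compound 4 (within the scatter). The earlier compounds shown here offered no step at this place, and this pair shows that the read-out does not separate the triple bond from the double bond here. No measurement shown accounts for this result.

Going by these compounds, whether a longer chain in place of 2-phenylethynyl, or an amine on its phenyl ring, would keep the number stays open. So does whether the same exchange would read alike on the core of compound 1.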